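Chloroacetyl versus arylsulfonyl at the distal piperazine nitrogen

The source may report more compounds than this note shows. Statements on the series, on what has been measured and on what is new or still open speak of the compounds shown alone.

Measured compounds:
compound 1 `CCN(CC)c1ccc2cc(C(=O)c3ccc(N4CCN(C(=O)CN5CCN(C(=O)CCl)CC5)CC4)cc3)oc2c1` — 5520 nM
compound 2 `CCN(CC)c1ccc2cc(C(=O)c3ccc(N4CCN(C(=O)CN5CCN(S(=O)(=O)c6ccc(C(F)(F)F)cc6)CC5)CC4)cc3)oc2c1` — > 40000 nM

Among the compounds with values here, in a functional assay on HeLa cells (Homo sapiens) for cytotoxicity, read by MTT assay, with a stated time of 48 h (on this read-out lower numbers stand for stronger inhibition and higher numbers for weaker inhibition), compound 1 gives 5520 nM, the only numerical value in the set. Compound 2 reaches only (the limit of > 40000 nM in this assay, at which 1 of the 2 values shown sits), a limit rather than a number. Compound 3 `CCN(CC)c1ccc2cc(C(=O)c3ccc(N4CCN(C(=O)CN5CCN(S(=O)(=O)c6ccc(C#N)cc6)CC5)CC4)cc3)oc2c1` carries (4-cyanophenyl)sulfonyl in place of (chloromethyl)carbonyl on an amine nitrogen in a ring, that is, (4-cyanophenyl)sulfonyl in place of (chloromethyl)carbonyl on an amine nitrogen in a ring. Within the data shown here, no measured step covers this change; compound 2 shows that an arylsulfonyl group at this nitrogen coincides with a limit. The step of a 6.3-fold higher number from compound 1 to compound 3 (0.80 log units; beyond the scatter) is expected to be a sizeable loss. Compound 3 is estimated at 35000 nM, within 12000 nM to 90000 nM, with a fair chance that this assay again returns only a limit.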

Compound 3, half-maximal inhibitory concentration: 8470 nM
The estimate for compound 3 lay 4.1-fold (0.62 log units) above the measured number; the whole stated range lies above it.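

In this assay, (4-cyanophenyl)sulfonyl can stand in place of (chloromethyl)carbonyl on this amine nitrogen with a 1.5-fold higher number from compound 1 to compound 3 (0.19 log units; within the scatter), so a measured number here does not depend on the (chloromethyl)carbonyl group. An arylsulfonyl group at this nitrogen does not by itself go with a limit, since cyano in place of trifluoromethyl on an aromatic carbon gives an at least 4.7-fold lower number from compound 2 to compound 3 (0.67 log units; beyond the scatter). Compound 2 remains a limit, not a number: the limit of > 40000 nM in this assay, at which 1 of the 3 values shown sits.

On these data alone, whether a methoxy group, a fluorine or an unsubstituted phenyl ring on the sulfonyl group would fall with cyano or with trifluoromethyl remains open. Also open, as far as these compounds go, is how a plain acetyl group on this nitrogen would compare with (chloromethyl)carbonyl.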